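Swapping ethoxy for amino on a carbonyl carbon

The source may report more compounds than this note shows. Statements on the series, on what has been measured and on what is new or still open speak of the compounds shown alone.

Values from a functional assay on NALM-6 cells (Homo sapiens) for cytotoxicity, with a stated time of 72 h (a higher number here means that more compound is needed for the effect, a lower number that less compound is needed), are available for three compounds.
- Compound 1 `C=C[C@@](C)(/C=C/c1ccc(O)cc1)CCC(O)C(C)(C)O` gives > 43400 nM (a limit, not a number)
- Compound 2 `C=C[C@@](C)(/C=C/c1ccc(O)c(/C=C/C(=O)c2ccccc2)c1)CCC=C(C)C` gives 4470 nM
- Compound 3 `C=C[C@@](C)(/C=C/c1ccc(O)c(/C=C/C(=O)OCC)c1)CCC=C(C)C` gives 20900 nM

Of the two true numbers, the higher belongs to compound 3, so more of it is needed for the effect than of compound 2. Compound 4 `C=C[C@@](C)(/C=C/c1ccc(O)c(/C=C/C(N)=O)c1)CCC=C(C)C` has not yet been measured. It differs from compound 3 in one place: amino in place of ethoxy on a carbonyl carbon.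

For the measured compounds named here, only one measured step changes this same carbonyl carbon. It runs a 4.7-fold higher number from compound 2 to compound 3 (0.67 log units; beyond the scatter), as ethoxy takes the place of phenyl. Going by the values given here, this modest step shows that the group here can shift the value, but no measured compound carries amino at this carbon. The direction of the new step is therefore uncertain, and no step beyond the scatter is the most likely outcome, though one of similar size remains possible. The expected change is a 1.2-fold higher number from compound 3 to compound 4 (0.08 log units; within the scatter) and it leans slightly upward. Compound 4 is estimated at 25000 nM, with an expected range from 8000 nM to 43400 nM in this assay for now.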

Compound 4, half-maximal effective concentration: > 43400 nM
Compound 4 was reported as a limit (the forecaster's own chance of this, stated with the estimate: 20%); middle value at least 1.7-fold (0.23 log units) from the limit.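

In this assay compound 4 gives > 43400 nM, which is a limit and not a number, and the same limit appears elsewhere in this set: the limit of > 43400 nM in this assay, at which 2 of the 4 values shown sit. On this carbonyl carbon, amino in place of ethoxy gives an at least 2.0-fold higher number from compound 3 to compound 4 (0.31 log units; beyond the scatter), while amino in place of phenyl gives an at least 9.7-fold higher number from compound 2 to compound 4 (0.98 log units; beyond the scatter). With three groups now compared at this carbon, the order is clear: phenyl needs the least compound, ethoxy more and amino the most, so a small amino group brings no gain here.

On these data alone, how far the true value of compound 4 lies past the limit remains open, so the full size of both steps is unknown. Also open, as far as these compounds go, is whether methylamino, hydroxy or a longer alkoxy chain on this carbonyl carbon would fall nearer to phenyl or to amino.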